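From 3,4-dimethylphenyl to phenyl on an amine nitrogen

A few compounds are considered here, and "the series" means these few. Any claim that something is new, unique, unknown or untested is made for them only; others in the source may bear on it.

Compound 1 `CCCc1ccc(NC2=CC(=O)c3nc4n(c3C2=O)[C@H]2OC[C@@H](O)[C@H]2OC4)cc1` gives 4990 nM
Compound 2 `Cc1ccc(NC2=CC(=O)c3nc4n(c3C2=O)[C@H]2OC[C@@H](O)[C@H]2OC4)cc1C` gives 2690 nM

For the measured compounds named here, both numbers come from a functional assay on HeLa cells (Homo sapiens) for inhibition, read by sulforhodamine B assay (a lower number here means a stronger inhibitor, a higher number a weaker inhibitor), and they lie within the scatter of each other, so compound 2 cannot be separated from compound 1 on the numbers so far. Going by the values given here, compound 3 `O=C1C=C(Nc2ccccc2)C(=O)c2c1nc1n2[C@H]2OC[C@@H](O)[C@H]2OC1` keeps the shared core and has phenyl in place of 3,4-dimethylphenyl on an amine nitrogen as its only change. Among the compounds with values here, one measured step bears on this place, and it is a 1.9-fold lower number from compound 1 to compound 2 (0.27 log units; within the scatter) for the swap of 4-propylphenyl for 3,4-dimethylphenyl. Within the data shown here, no measured compound yet carries phenyl itself, so the evidence is indirect. No step beyond the scatter is therefore expected in this assay in either direction. The expected change is a 1.1-fold higher number from compound 2 to compound 3 (0.05 log units; within the scatter) as estimated here. Compound 3 is expected at 3000 nM within an estimated range of 1200 nM to 8000 nM in this measurement.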

Compound 3, half-maximal inhibitory concentration: 5620 nM
The estimate for compound 3 lay 1.9-fold (0.27 log units) below the measured number, within the range that was stated.
By their numbers in this assay, from the lowest: compounds 2, 1 and 3 (each within the scatter of the next, the first and the last beyond it).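

In this assay, for the compounds shown here, going from 3,4-dimethylphenyl to phenyl on the amine nitrogen gives a 2.1-fold higher number from compound 2 to compound 3 (0.32 log units; beyond the scatter) and so is the only step at this place that passes the scatter, though modestly. Hydrogen in place of propyl on an aromatic carbon gives a 1.1-fold higher number from compound 1 to compound 3 (0.05 log units; within the scatter) and leaves phenyl and 4-propylphenyl unresolved, so 3,4-dimethylphenyl is separated from phenyl but not from 4-propylphenyl. No evidence is available to account for the step.

On these data alone, it remains open whether a single methyl group on the phenyl ring would be enough to give the lower number seen with 3,4-dimethylphenyl. As far as these compounds go, it is also open how a methoxy group, a chlorine, a carboxylic acid or a chain longer than propyl on that ring would read in this assay.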